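A few compounds are considered here, and "the series" means these few. Any claim that something is new, unique, unknown or untested is made for them only; others in the source may bear on it.

Compound 1, `C=C1C(=O)[C@]23C[C@@]1(O)CC[C@H]2c1ccc(OS(=O)(=O)c2ccc(C)cc2)c(C)c1[C@@H]3Cn1cc(-c2ccc(Br)cc2)nn1`, gives 1630 nM in a functional assay on A549 cells (Homo sapiens) for cytotoxicity, read by MTT assay, with a stated time of 4 days; on this read-out lower numbers stand for stronger inhibition and higher numbers for weaker inhibition.
Compound 2, `C=C1C(=O)[C@]23C[C@@]1(O)CC[C@H]2c1ccc(OS(=O)(=O)c2ccc(C)cc2)c(C)c1[C@@H]3Cn1cc(-c2ccc(Cl)cc2)nn1`, gives 1870 nM in this assay.
Compound 3, `C=C1C[C@]23C[C@@]1(O)CC[C@@H]2c1cccc(C)c1[C@@H]3Cn1cc(-c2ccc(Cl)cc2)nn1`, gives no number in this assay but only the limit > 20000 nM.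

The first two compounds share a core and differ in one place: the change from compound 2 to compound 1 is bromo in place of chloro on an aromatic carbon. In this assay this change made a 1.1-fold lower number from compound 2 to compound 1 (0.06 log units; within the scatter), so the two values cannot be told apart. Compound 3 carries a different core, and the difference between the core of compound 2 and the core of compound 3 is not broken down here. For compound 3 the value stands at the limit of > 20000 nM in this assay, at which 1 of the 3 values shown sits.

Compound 4, `C=C1C[C@]23C[C@@]1(O)CC[C@@H]2c1cccc(C)c1[C@@H]3Cn1cc(-c2ccc(Br)cc2)nn1`, has not yet been measured. It differs from compound 3 by bromo in place of chloro on an aromatic carbon, the same change that separates compound 2 from compound 1, at the same kind of place. Since that change left compound 1 and compound 2 within the scatter of each other, the step from compound 3 to compound 4 in this assay is expected to be small as well, estimated as a step that the limit leaves unreadable from compound 3 to compound 4. Because compound 3 sits at the limit of > 20000 nM in this assay, at which 1 of the 3 values shown sits, compound 4 is expected to give a limit rather than a number. As a working estimate for compound 4 in this assay the value 25000 nM is taken, expected between 10000 nM and 60000 nM.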

Compound 4, half-maximal inhibitory concentration: > 20000 nM
Compound 4 was reported as a limit; the forecaster's own chance of this, stated with the estimate: 85%; the middle value does not contradict the limit.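

In this assay compound 4 gives > 20000 nM as a limit. Compound 3 also stands at a limit, so no step can be read between compound 3 and compound 4, and the change from chloro to bromo on this core remains unsized: the limit of > 20000 nM in this assay, at which 2 of the 4 values shown sit. The compounds shown leave open how far past the limit compound 3 and compound 4 each lie, and whether their true values differ.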